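The source may hold more compounds than are shown below. What is called first, only, known or untested is meant among the compounds shown, and "the series" means these compounds.

Among the compounds with values here, compound 1 `CNC(=O)/C=C/CNCCOc1ccc(Oc2c(-c3ccc(F)cc3)sc3cc(O)ccc23)cc1` gives 15500 nM in a functional assay on Ishikawa cells (Homo sapiens) for antiproliferative activity, read by CCK-8 assay, with a stated time of 48 h (on this read-out higher numbers stand for weaker inhibition and lower numbers for stronger inhibition), the largest of the three numbers measured so far, with compound 3 nearest and compound 2 furthest, both within the scatter. Compound 2 `O=C(/C=C/CNCCOc1ccc(Oc2c(-c3ccc(F)cc3)sc3cc(O)ccc23)cc1)N1CCCCC1` gives 8430 nM, and compound 3 `O=C(/C=C/CN1CC(Oc2ccc(Oc3c(-c4ccc(F)cc4)sc4cc(O)ccc34)cc2)C1)N1CCCC1` gives 9150 nM. Compound 4 `O=C(/C=C/CNCCOc1ccc(Oc2c(-c3ccc(F)cc3)sc3cc(O)ccc23)cc1)N1CCCC1` differs from compound 1 in one place: pyrrolidin-1-yl in place of methylamino on a carbonyl carbon. Within the data shown here, the only measured step that bears on this is a 1.8-fold lower number from compound 1 to compound 2 (0.26 log units; within the scatter), where a six-membered ring entered at the same carbonyl carbon. Compound 3 carries pyrrolidin-1-yl on its carbonyl carbon, with a different linker, and its number sits close to that of compound 2. For compound 4 the expected step is therefore a 1.7-fold lower number from compound 1 to compound 4 (0.24 log units; within the scatter), nothing beyond the scatter. Compound 4 is estimated at 9000 nM, between 4500 nM and 18000 nM.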

Compound 4, half-maximal inhibitory concentration: 11300 nM
Compound 4: middle estimate off by 1.3-fold (0.10 log units), on the low side; the range from low to high includes it.
By their numbers in this assay, from the lowest: compounds 2, 3, 4 and 1 (each within the scatter of the next).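

Pyrrolidin-1-yl in place of methylamino on the carbonyl carbon gives a 1.4-fold lower number from compound 1 to compound 4 (0.14 log units; within the scatter), and pyrrolidin-1-yl in place of piperidin-1-yl gives a 1.3-fold higher number from compound 2 to compound 4 (0.13 log units; within the scatter). Across these three compounds, then, neither bringing in a ring nor changing its size from six to five members moves the number beyond the scatter. No measurement here offers an explanation for these small differences.

Still open, on these data alone, is whether a group with a second ring hetero atom, such as morpholin-4-yl, or an open-chain dimethylamino at this carbonyl carbon would produce a step beyond the scatter.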